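From Propyl to Ethyl at the Ring Nitrogen Side Chain

A few compounds are considered here, and "the series" means these few. Any claim that something is new, unique, unknown or untested is made for them only; others in the source may bear on it.

Compound 1 `CCCN(Cc1ccccc1)c1nc(C)nc(Nc2c(C)cc(C)cc2C)n1`: 490 nM
Compound 2 `CCCN(CCC)c1nc(C)nc(Nc2c(C)cc(C)cc2C)n1`: 130 nM

Compound 1 has the highest number of the two in an assay on isolated protein for binding affinity to corticotropin-releasing factor receptor 1 (Homo sapiens); on this read-out lower numbers stand for stronger inhibition and higher numbers for weaker inhibition; its nearest neighbour is compound 2, and the step of a 3.8-fold lower number from compound 1 to compound 2 (0.58 log units; beyond the scatter) is a modest one. Compound 3 `CCN(Cc1ccccc1)c1nc(C)nc(Nc2c(C)cc(C)cc2C)n1` differs from compound 1 by hydrogen in place of methyl on a saturated chain carbon, two bonds along the chain from a nitrogen on an aromatic ring, that is, propyl to ethyl. Within the data shown here, the only measured step swaps phenyl for ethyl and so concerns a different part of the chain; no measured step bears directly on this change. The step of no change at the digits printed from compound 1 to compound 3 (within the scatter) is therefore expected not to exceed the scatter. The estimate for compound 3 is 490 nM, with a range from 200 nM to 1200 nM.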

Compound 3, inhibition constant: 1470 nM
Estimate against measurement, compound 3: 3.0-fold (0.48 log units) below; measured number outside the range, above it.
By their numbers in this assay, from the lowest: compound 2; then compound 1; then compound 3.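

Replacing propyl with ethyl gives a 3.0-fold higher number from compound 1 to compound 3 (0.48 log units; beyond the scatter) in this assay at this position, so the end of this chain matters to the read-out, although it differs by a single methyl. The earlier pair changed only the other chain on this nitrogen and showed nothing about this carbon. Nothing available explains why the number rises with this change.

On these data alone, it remains open whether a longer chain such as butyl, or a branched one such as isopropyl, would lower the number here. As far as these compounds go, it is also open whether the same shortening would read alike on compound 2, which carries propyl on both sides.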